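The source may report more compounds than this note shows. Statements on the series, on what has been measured and on what is new or still open speak of the compounds shown alone.

Of the compounds shown here, two have been tested. Compound 1 `CCCCC(=O)ON1C(=O)COc2c(Cl)cccc21` gives, in an ADME assay on the whole organism for inhibition, with Oryza sativa as the target, with a stated time of 7 days (a lower number here means a stronger inhibitor, a higher number a weaker inhibitor), a value of 712000 nM. Compound 2 `CCC(=O)ON1C(=O)COc2ccc(F)cc21` gives in this assay a value of 3000 nM, the lower of the two numbers; its nearest neighbour is compound 1, whose number lies far above it, well beyond the scatter. Compound 3 `CCCCC(=O)ON1C(=O)COc2ccc(F)cc21` has not yet been measured. It differs from compound 2 by a single change: ethyl in place of hydrogen on a saturated chain carbon, two bonds along the chain from a carbonyl carbon. Within the data shown here, compound 1 carries the same longer chain, but differs from compound 2 in more than one place, so no clean step for this change exists. Compound 3 is therefore expected to sit somewhat above compound 2 in this assay, with a step of a 2.7-fold higher number from compound 2 to compound 3 (0.43 log units; beyond the scatter) that may or may not exceed the scatter. For compound 3 a value near 8000 nM is estimated, within the range 2000 nM to 40000 nM.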

Compound 3, half-maximal inhibitory concentration: 6000 nM
Estimate against measurement, compound 3: 1.3-fold (0.12 log units) above; measured number inside the range.
By their numbers in this assay, from the lowest: compounds 2 and 3 (each within the scatter of the next); then compound 1.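

Among these compounds, for the first time this position has a clean step: in this assay, ethyl in place of hydrogen on a saturated chain carbon, two bonds along the chain from a carbonyl carbon, gives a 2.0-fold higher number from compound 2 to compound 3 (0.30 log units; within the scatter), so the propanoyl and the longer chain cannot be told apart on this core. Among the compounds shown here, the far higher number of compound 1 therefore finds no counterpart in this single change, though that compound differs from compound 2 in more than one place. Nothing at hand gives a measured reason for this result.

Going by these compounds, it remains open whether a longer chain, a phenyl ring, or an amine or carboxylic acid at the chain end would also stay within the scatter of compound 2. For the compounds shown here, it is also open which of the differences in compound 1 goes with its number, as no single-change pair links it to the others.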